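Small acyl extension on a weak antiproliferative compound

This account rests on a few compounds, and the source may have more. Where it says the series, first, only, none or still open, it means among the compounds named here.

Compound 1 `CCOC(=O)c1csc2nc(CN3CCN(Cc4ccccc4)CC3)c(-c3ccc(C)cc3)n12` gives 29100 nM
Compound 2 `Cc1ccc(-c2c(CN3CCCCC3)nc3scc(C(=O)O)n23)cc1` gives 8290 nM
Compound 3 `CC(=O)NNC(=O)c1csc2ncc(-c3ccc(C)cc3)n12` gives 57300 nM

All three compounds were tested in a functional assay on MCF7 cells (Homo sapiens) for antiproliferative activity, read by MTT assay, with a stated time of 72 h (on this read-out higher numbers stand for weaker inhibition and lower numbers for stronger inhibition), and no two of them differ in only one place. Compound 3 at 57300 nM lies within the scatter of compound 1 at 29100 nM and carries a higher number, meaning weaker inhibition, than compound 2 at 8290 nM by a margin beyond the scatter.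

Compound 4 `CCC(=O)NNC(=O)c1csc2ncc(-c3ccc(C)cc3)n12` has not yet been measured. It differs from compound 3 by methyl in place of hydrogen on a saturated chain carbon bound to a carbonyl carbon so that acetyl becomes propanoyl. Within the data shown here, the measured compounds offer no single-place step as a guide. In this assay no step beyond the scatter is expected, in either direction. The expected size of the change, a 1.3-fold lower number from compound 3 to compound 4 (0.10 log units; within the scatter) as estimated here, stays within the scatter. For compound 4 the estimated value is 45000 nM with an expected range from 20000 nM to 90000 nM for the measurement.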

Compound 4, half-maximal inhibitory concentration: 5190 nM
For compound 4 the middle estimate is 8.7-fold (0.94 log units) above the measured one; measured number below the stated range.
By their numbers in this assay, from the lowest: compounds 4 and 2 (each within the scatter of the next); then compounds 1 and 3 (each within the scatter of the next).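

In this assay, among these compounds, the first step that can be read at a single place is large: methyl in place of hydrogen on a saturated chain carbon bound to a carbonyl carbon, which turns acetyl into propanoyl, gives an 11-fold lower number from compound 3 to compound 4 (1.04 log units; beyond the scatter) in the direction of stronger inhibition. Among the compounds shown here, this shows what the earlier compounds, no two of which differed in only one place, could not: at this position, 1 heavy atom, with no ring, hydrogen-bond donor, hydrogen-bond acceptor or net charge, is enough for a change beyond the scatter. Nothing measured here accounts for the size of this step.

The compounds shown leave open whether a longer chain such as butanoyl would keep, extend or lose this gain. They also leave open how an amine or a carboxylic acid at the end of the propanoyl chain would read out.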